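This account rests on a few compounds, and the source may have more. Where it says the series, first, only, none or still open, it means among the compounds named here.

Measured so far:
- compound 1 `COc1ccccc1OCCNc1ccc(=O)n(Cc2ccc(OC)c(OC3CCCC3)c2)n1`: > 100000 nM
- compound 2 `COc1ccc(Cn2ncc(NCCOc3ccccc3OC)c(Cl)c2=O)cc1OC`: > 100000 nM

In a functional assay on AGS cells (Homo sapiens) for antiproliferative activity, read by MTT assay, with a stated time of 48 h (on this read-out lower numbers stand for stronger inhibition of growth and higher numbers for weaker inhibition of growth), compound 1 gives > 100000 nM, which is a limit and not a number. Compound 2 gives > 100000 nM, also a limit. Compound 2 therefore has no numeric standing in the series: the limit of > 100000 nM in this assay, at which 2 of the 2 values shown sit.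

Compound 3 `COc1ccccc1OCCNc1cnn(Cc2ccc(OC)c(OC3CCCC3)c2)c(=O)c1Cl` follows from compound 2 by a single change, cyclopentyl in place of methyl on an oxygen on an aromatic ring. Within the data shown here, no measured step shows what this change does in this assay. Compound 1, which already carries cyclopentyloxy, gives > 100000 nM, again a limit, so only a small gain is expected. The estimated at least 1.2-fold lower number from compound 2 to compound 3 (0.09 log units; that floor lies within the scatter) is modest, towards stronger inhibition of growth, and another limit result would not surprise. For compound 3 the estimate is 80000 nM, with an expected range of 25000 nM to 100000 nM.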

Compound 3, concentration for 50% growth inhibition: > 100000 nM
Compound 3 was reported as a limit (the forecaster's own chance of this, stated with the estimate: 65%); middle value at least 1.2-fold (0.09 log units) from the limit.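

No step can be read between compound 2 and compound 3, because both results are limits and not numbers: the limit of > 100000 nM in this assay, at which 3 of the 3 values shown sit.

The compounds shown leave open whether methoxy to cyclopentyloxy changes growth inhibition at all, and which compound of this series would give a numeric value.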